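A few compounds are considered here, and "the series" means these few. Any claim that something is new, unique, unknown or untested is made for them only; others in the source may bear on it.

The measured compounds are:

compound 1, `Cc1ccc(-n2c(S)nnc2COc2ccc(-c3ccccc3)cc2)c(C)c1`, with 54.5% in a functional assay on the whole organism (strain Wistar) for inhibition, with Rattus norvegicus as the target, read by paw edema, with a stated time of 3 h, at a dose of 10 mg/kg by the oral route; a lower number here means less inhibition, a higher number more inhibition at the dose given (going by the name of the read-out);
compound 2, `CCCCNc1nnc(COc2ccc(-c3ccccc3)cc2)s1`, with 27.3%;
compound 3, `Brc1ccc(Nc2nnc(COc3ccc(-c4ccccc4)cc3)s2)cc1`, with 63.6%.

Compound 3 has the highest of the three numbers in this assay. Its nearest neighbour is compound 1, whose number is lower by an amount that lies within the scatter, so the two cannot be ordered; compound 2 lies furthest away, beyond the scatter.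

The next compound, compound 4, is `Cc1ccccc1Nc1nnc(COc2ccc(-c3ccccc3)cc2)s1`. It differs from compound 3 in one place: 2-methylphenyl in place of 4-bromophenyl on a nitrogen on an aromatic ring.

Among the compounds with values here, only one measured step exists, and it touches the same nitrogen: a number 36.3 percentage points higher from compound 2 to compound 3 (beyond the scatter). That step exchanged a chain for an aromatic ring, whereas the change to compound 4 exchanges one aromatic ring for another of the same size. Within the data shown here, no measured pair shows such an aryl-for-aryl swap, so the large step from compound 2 to compound 3 gives a direction only weakly, and a step within the scatter is expected for a number 8.6 percentage points lower from compound 3 to compound 4 (within the scatter). Compound 4 is therefore estimated at 55%, with a range from 35% to 70%.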

Compound 4, a percentage reported as inhibition, in the whole organism at one dose (the size of the read-out at that dose, not a potency): 25%
The estimate for compound 4 lay 30 percentage points above the measured number; measured number outside the range, below it.
By their numbers in this assay, from the lowest: compounds 4 and 2 (each within the scatter of the next); then compounds 1 and 3 (each within the scatter of the next).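

In this assay, an aromatic ring on this nitrogen does not by itself bring the higher number: with 4-bromophenyl and 2-methylphenyl matching in heavy atoms and in donor and acceptor counts, the swap still gives a number 38.6 percentage points lower from compound 3 to compound 4 (beyond the scatter), a step printed as large. Exchanging butyl for 2-methylphenyl gives a number 2.3 percentage points lower from compound 2 to compound 4 (within the scatter), so the large gain seen earlier with 4-bromophenyl does not extend to every aryl group at this place. Nothing available explains why this exchange matters so much here.

Going by these compounds, whether the gap between compound 3 and compound 4 follows the bromine or the methyl group remains open, and a plain phenyl group on this nitrogen would help separate the two. On these data alone, how a longer chain than butyl or a chlorophenyl group would fare at this place is also open.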